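The source may report more compounds than this note shows. Statements on the series, on what has been measured and on what is new or still open speak of the compounds shown alone.

Measured compounds:

- Compound 1, `CC(C(=O)NCc1ccc(C(C)(C)C)nc1N1CCC(Cc2ccccc2)CC1)c1ccc(NS(C)(=O)=O)c(F)c1`: 0.3 nM
- Compound 2, `CCCOc1cc(C(C)(C)C)ccc1CNC(=O)C(C)c1ccc(NS(C)(=O)=O)c(F)c1`: 4.4 nM

In an assay on cells for antagonist activity at transient receptor potential cation channel subfamily V member 1 (Homo sapiens), read by FLIPR and calcium flux, with a stated time of 6 min (on this read-out lower numbers stand for stronger inhibition and higher numbers for weaker inhibition), compound 2 gives the higher of the two numbers, and compound 1 gives a number that is lower by a gap beyond the usual scatter, so compound 1 is the more potent of the pair. These two compounds differ in several places at once, so no single change can be read from that gap.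

Compound 3, `CC(C(=O)NCc1ccc(C(C)(C)C)cc1SC1CCCCC1)c1ccc(NS(C)(=O)=O)c(F)c1`, differs from compound 2 in one place: cyclohexylsulfanyl in place of propoxy on an aromatic carbon. Among the compounds with values here, no measured pair isolates this change, so the expectation rests mainly on compound 2 and its own value of 4.4 nM. The step of a 1.5-fold lower number from compound 2 to compound 3 (0.17 log units; within the scatter) is expected to be small, at most a modest move toward a lower number, and quite possibly within the scatter. Compound 3 is therefore estimated at 3 nM, with a likely range from 0.7 nM to 15 nM.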

Compound 3, inhibition constant: 7.4 nM
For compound 3 the middle estimate is 2.5-fold (0.39 log units) below the measured one; the measured number falls inside the stated range.
By their numbers in this assay, from the lowest: compound 1; then compounds 2 and 3 (each within the scatter of the next).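

In this assay, replacing propoxy with cyclohexylsulfanyl gives a 1.7-fold higher number from compound 2 to compound 3 (0.23 log units; within the scatter), so compound 2 and compound 3 cannot be told apart. This position, ortho to a large group and meta to a tert-butyl group, therefore accepts a bulkier substituent with more heavy atoms, a six-membered non-aromatic carbon ring and sulfur in place of oxygen, without a change beyond the scatter. No measurement shown here gives a reason for this result.

From the compounds shown here alone, what remains open is whether this position stays as accommodating with a charged or strongly different substituent, such as an amine or a carboxylic acid. A much smaller group such as methoxy also remains untested among the compounds shown, so the lower limit on substituent size at this position is unknown.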